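The source may report more compounds than this note shows. Statements on the series, on what has been measured and on what is new or still open speak of the compounds shown alone.

Measured in a functional assay on IGROV-1 cells (Homo sapiens) for antiproliferative activity, read by sulforhodamine B assay, with a stated time of 48 h; on this read-out lower numbers stand for stronger inhibition and higher numbers for weaker inhibition:
- compound 1 `O=C(NCCCNc1cc(-c2cn(-c3ccccc3)nc2-c2cccc(O)c2)ccn1)Nc1ccc(F)cc1`: 1230 nM
- compound 2 `O=C(NCCCNc1cc(-c2cn(-c3ccccc3)nc2-c2cccc(O)c2)ccn1)Nc1cccc(C(F)(F)F)c1`: 2830 nM

Of these two numbers, compound 1 holds the lower, and compound 2 is its nearest neighbour. Compound 3 `COc1cccc(-c2nn(-c3ccccc3)cc2-c2ccnc(NCCCNC(=O)Nc3ccc(F)cc3)c2)c1` departs from compound 1 by methyl in place of hydrogen on an oxygen on an aromatic ring, that is, 3-hydroxyphenyl to 3-methoxyphenyl. Among the measured compounds shown here, the sole measured step, a 2.3-fold higher number from compound 1 to compound 2 (0.36 log units; beyond the scatter), lies elsewhere, on an amide-type nitrogen, so it gauges only the size of steps in this small set. For the measured compounds named here, no measured compound carries the methoxy group, and the direction of the change is therefore open. A modest move toward a higher number in this assay is expected, of similar size to that step. The estimated step is a 1.6-fold higher number from compound 1 to compound 3 (0.21 log units; within the scatter). Compound 3 is expected at 2000 nM, with an estimated range of 700 nM to 6000 nM.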

Compound 3, half-maximal inhibitory concentration: 9340 nM
Compound 3: middle estimate off by 4.7-fold (0.67 log units), on the low side; the measured number lies above the stated range.
By their numbers in this assay, from the lowest: compound 1; then compound 2; then compound 3.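

In this assay, methyl in place of hydrogen on the oxygen of the 3-hydroxyphenyl group gives a 7.6-fold higher number from compound 1 to compound 3 (0.88 log units; beyond the scatter), so this position does respond to substitution, and hydroxy carries the lower number of the two groups seen here. Among the compounds shown here, this step is larger than a 2.3-fold higher number from compound 1 to compound 2 (0.36 log units; beyond the scatter), the only other step available, so in this small set the change on the oxygen moves the number further than the change on the amide-type nitrogen. Nothing at hand bears on why the number rises with methoxy.

Still open, from the compounds shown here alone, is whether the rise is particular to methoxy, since an amine, a carboxylic acid or an ethoxy group in place of hydroxy would show how far this position tolerates change. Also open, going by these compounds, is whether the same step holds with the 3-(trifluoromethyl)phenyl group of compound 2 in place of 4-fluorophenyl.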